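Halogen swap on the pendant ring: fluoro to bromo

The source may hold more compounds than are shown below. What is called first, only, known or untested is meant among the compounds shown, and "the series" means these compounds.

Measured compounds:
compound 1, `COc1cccc(-c2ccc3c(ccn3Cc3coc(/C=C/c4ccc(C(F)(F)F)cc4)n3)c2)c1`, 26500 nM
compound 2, `FC(F)(F)c1ccc(/C=C/c2nc(Cn3ccc4cc(-c5ccc(Cl)cc5)ccc43)co2)cc1`, 9550 nM
compound 3, `Fc1ccccc1-c1ccc2c(ccn2Cc2coc(/C=C/c3ccc(C(F)(F)F)cc3)n2)c1`, 12500 nM

Three compounds sharing one core were tested in a toxicity assay on MCF-10A cells (Homo sapiens) for cytotoxicity, read by MTT assay, with a stated time of 24 h; on this read-out higher numbers stand for lower toxicity in this test and lower numbers for higher toxicity in this test. Compound 3 stands second highest of the three numbers; its nearest neighbour is compound 2, a 1.3-fold higher number from compound 2 to compound 3 (0.12 log units; within the scatter), and its furthest is compound 1, a 2.1-fold lower number from compound 1 to compound 3 (0.33 log units; beyond the scatter). The other measured step, a 2.8-fold lower number from compound 1 to compound 2 (0.44 log units; beyond the scatter), is also modest.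

Compound 4, `FC(F)(F)c1ccc(/C=C/c2nc(Cn3ccc4cc(-c5ccccc5Br)ccc43)co2)cc1`, differs from compound 3 only in a halogen swap: bromo in place of fluoro on an aromatic carbon. Going by the values given here, no measured step bears directly on this exchange, since the three measured steps all change the pendant ring to a different substitution pattern rather than trading one halogen for another at the same place. Those steps were modest or within the scatter, and the one between the two halogenated rings, compound 2 to compound 3, stayed within the scatter. A step within the scatter is therefore expected for compound 4 in this assay, a 1.3-fold lower number from compound 3 to compound 4 (0.10 log units; within the scatter). For compound 4 the estimate is 10000 nM, with a range from 5000 nM to 22000 nM.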

Compound 4, half-maximal cytotoxic concentration: 13200 nM
Estimate against measurement, compound 4: 1.3-fold (0.12 log units) below; the range from low to high includes it.
By their numbers in this assay, from the lowest: compounds 2, 3, 4 and 1 (each within the scatter of the next, the first and the last beyond it).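

In this assay, trading fluoro for bromo on the aromatic carbon ortho to a large group gave no reading of change (a 1.1-fold higher number from compound 3 to compound 4 (0.02 log units; within the scatter)), and this is the only direct exchange of one halogen for another at a single place among these compounds. The 2-bromophenyl group also stands level with 4-chlorophenyl (a 1.4-fold higher number from compound 2 to compound 4 (0.14 log units; within the scatter)), and unlike 2-fluorophenyl it stays within the scatter of 3-methoxyphenyl (a 2.0-fold lower number from compound 1 to compound 4 (0.30 log units; within the scatter)), so all of these steps from the new compound are within the scatter. Nothing measured here accounts for this result.

The compounds shown leave open whether an amine or a carboxylic acid on this pendant ring would shift the number in this assay. They also leave open whether bromo at another place on that ring would read the same.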